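Pyrazolopyrimidinone thioethers: swapping pyridyl for phenyl at the chain carbon

A few compounds are considered here, and "the series" means these few. Any claim that something is new, unique, unknown or untested is made for them only; others in the source may bear on it.

Measured so far:
Compound 1, `CC(C)C(Sc1nc2c(cnn2C)c(=O)n1-c1ccccc1)c1ccccc1`, in an assay on isolated protein for inhibition of aldehyde dehydrogenase 1A1 (Homo sapiens) (a higher number here means a weaker inhibitor, a lower number a stronger inhibitor), gives 380 nM.
Compound 2, `CC(Sc1nc2c(cnn2C)c(=O)n1-c1ccccc1)c1cccc(F)c1`, in this assay gives 151 nM.
Compound 3, `CC(Sc1nc2nn(C3COC3)cc2c(=O)n1-c1ccccc1)c1ccccn1`, in this assay gives 68 nM.

Compound 3 has the lowest number of the three in this assay; the gaps to compound 2 and to compound 1 are both beyond the usual scatter. Compound 4, `CC(Sc1nc2nn(C3COC3)cc2c(=O)n1-c1ccccc1)c1ccccc1`, is not yet measured. It differs from compound 3 in one place: phenyl in place of pyridin-2-yl on a saturated chain carbon bound to a saturated chain carbon and a sulfur. Within the data shown here, no pair of measured compounds isolates this change, so no step can be read off for it; compounds 1 and 2 differ from compound 4 in more than one place. The expectation is a modest weakening, roughly at the edge of the scatter. Compound 4 is expected at 130 nM, within 45 nM to 400 nM. The expected step is a 1.9-fold higher number from compound 3 to compound 4 (0.28 log units; within the scatter).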

Compound 4, half-maximal inhibitory concentration in the aldehyde dehydrogenase 1A1 assay: 109 nM
Beside the measured number, compound 4's estimate is 1.2-fold (0.08 log units) above it; measured number inside the range.
By their numbers in the aldehyde dehydrogenase 1A1 assay, from the lowest: compounds 3, 4 and 2 (each within the scatter of the next, the first and the last beyond it); then compound 1.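

Among these compounds, this pair gives the first clean reading at this position: in the aldehyde dehydrogenase 1A1 assay the step is a 1.6-fold higher number from compound 3 to compound 4 (0.20 log units; within the scatter), so inhibition does not separate pyridin-2-yl from phenyl on this carbon. In a physicochemical assay for solubility, using the shake flask method, in phosphate buffer, with a stated time of 24 h, at pH 7.4 (a higher number here means a more soluble compound, a lower number a less soluble compound), compound 3 gives 60000 nM and compound 4 gives 26000 nM, and the same change does separate them: the measured solubility of compound 3, 60000 nM, and of compound 4, 26000 nM, a 2.3-fold lower number (0.36 log units; beyond the scatter)

Open, as far as these compounds go, is whether a pyrimidinyl ring or a morpholine at this carbon would keep this inhibition and how it would fare in the physicochemical assay. Also open, from the compounds shown here alone, is whether the swap reads the same with the other groups carried by compound 1 and compound 2.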